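The source may hold more compounds than are shown below. What is called first, only, known or untested is meant among the compounds shown, and "the series" means these compounds.

Compound 1 `COc1cc(NC(C)CCCNC(=O)NNC(=O)Nc2ccc(F)cc2)c2ncccc2c1` – 310 nM
Compound 2 `COc1cc(NC(C)CCCNC(=O)Nc2cccc(O)c2)c2ncccc2c1` – 11000 nM

In a functional assay on MCF7 cells (Homo sapiens) for inhibition, read by MTT assay, with a stated time of 72 h (a higher number here means a weaker inhibitor, a lower number a stronger inhibitor), compound 2 stands at 11000 nM, the higher of the two numbers and so the weaker inhibitor. Compound 3 `COc1cc(NC(C)CCCNC(=O)Nc2cccc(C(F)(F)F)c2)c2ncccc2c1` differs from it in one group, with trifluoromethyl in place of hydroxy on an aromatic carbon. Within the data shown here, no measured step makes this exact change. The only one available (a 35-fold higher number from compound 1 to compound 2 (1.55 log units; beyond the scatter)) was large, but it replaced a different and much bigger group, so it is a loose guide at best. A smaller move is therefore expected, leaning towards a lower number because compound 1 reaches 310 nM in this small set, and two compounds cannot settle that direction firmly. The expected step in this assay is modest (a 2.2-fold lower number from compound 2 to compound 3 (0.34 log units; beyond the scatter)). For compound 3 the estimated value is 5000 nM (1200 nM to 20000 nM).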

Compound 3, half-maximal inhibitory concentration: 3300 nM
Compound 3: middle estimate off by 1.5-fold (0.18 log units), on the high side; the measured number falls inside the stated range.
By their numbers in this assay, from the lowest: compound 1; then compound 3; then compound 2.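

In this assay, the direct swap on the ring gives a 3.3-fold lower number from compound 2 to compound 3 (0.52 log units; beyond the scatter), so a change of a single group at this position on the 3-hydroxyphenyl ring moves the number beyond the scatter. The bigger replacement still counts for more: with 3-(trifluoromethyl)phenyl in place of ((4-fluorophenyl)carbamoyl)amino, the result is an 11-fold higher number from compound 1 to compound 3 (1.03 log units; beyond the scatter), so the ring swap closes only part of the gap. No measured evidence is available to explain why the number moves at this position.

The compounds shown cannot separate the loss of hydroxy from the gain of trifluoromethyl, and a plain phenyl ring would provide that missing reference. They also leave open how an amine, a nitrile or a chlorine atom would behave on this same aromatic carbon.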